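Ether chain variation on the shared core

The source may report more compounds than this note shows. Statements on the series, on what has been measured and on what is new or still open speak of the compounds shown alone.

Compound 1 `O=c1c(-c2ccc(O)cc2)coc2cc(OCCOCCOCCO)ccc12` gives 40 nM in an assay (Cricetulus griseus) for inhibition of aldehyde dehydrogenase, mitochondrial (Homo sapiens); a higher number here means a weaker inhibitor, a lower number a stronger inhibitor. Compound 3 `CCOC(=O)CCCCOc1ccc2c(=O)c(-c3ccc(O)cc3)coc2c1` gives 240 nM in this assay, the highest of the two numbers shown; its nearest neighbour is compound 1, with a 6.0-fold higher number from compound 1 to compound 3 (0.78 log units; beyond the scatter). Compound 2 `O=C(O)CCCCCCCCCCCCCCCOc1ccc2c(=O)c(-c3ccc(O)cc3)coc2c1` returns only a limit, > 9000 nM, in this assay, so no number is known for it. That limit is the limit of > 9000 nM in this assay, at which 1 of the 3 values shown sits.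

Compound 4 `CCCCCCCCCCCCOc1ccc2c(=O)c(-c3ccc(O)cc3)coc2c1` differs from compound 3 by octyl in place of ethoxycarbonyl on a saturated chain carbon, four bonds along the chain from an oxygen on an aromatic ring. Going by the values given here, the one measured step that touches the same chain is a 6.0-fold higher number from compound 1 to compound 3 (0.78 log units; beyond the scatter), where the alteration sat two bonds along from the ring oxygen and the number rose by a modest amount. Compound 2, which carries a much longer chain on the same oxygen, reaches only a limit in this assay. Both observations point the same way for a long unbranched chain: the number is expected to move upward, beyond the scatter, with a real chance that only a limit is returned. The step from compound 3 to compound 4 is expected to be a 6.3-fold higher number from compound 3 to compound 4 (0.80 log units; beyond the scatter). Compound 4 is estimated to give 1500 nM in this assay, with a range from 400 nM to 9000 nM.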

Compound 4, half-maximal inhibitory concentration: > 9000 nM
Compound 4 was reported as a limit; the forecaster's own chance of this, stated with the estimate: 25%; at least 6.0-fold (0.77 log units) between middle value and limit.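

Working from the ethoxycarbonyl end of the chain, octyl in its place gives an at least 37-fold higher number from compound 3 to compound 4 (1.57 log units; beyond the scatter), and the comparison with the ether chain gives an at least 220-fold higher number from compound 1 to compound 4 (2.35 log units; beyond the scatter); both steps are large and go well past the modest rise seen earlier at this position. Compound 4 returns only a limit in this assay, > 9000 nM, so a chain end with no hydrogen-bond acceptors can reach the limit, and the carboxylic acid at the end of the chain in compound 2 is not required for that outcome. The step between compound 2 and compound 4 cannot be read, so these two cannot be ordered, and the top of the range is now shared: the limit of > 9000 nM in this assay, at which 2 of the 4 values shown sit.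

The compounds shown do not say how the number changes between the ethoxycarbonyl chain of compound 3 and the full length of compound 4, and a short unbranched chain such as butyl would help separate chain length from the loss of oxygen atoms. An amine at the chain end would show whether a group other than those ending compound 1 and compound 3 can keep the number low at this length.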